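The source may report more compounds than this note shows. Statements on the series, on what has been measured and on what is new or still open speak of the compounds shown alone.

Working notes on the series. In a functional assay on MCF7 cells (Homo sapiens) for cytotoxicity, read by MTT assay, with a stated time of 72 h (on this read-out lower numbers stand for stronger inhibition and higher numbers for weaker inhibition), compound 1 (`Nc1cccc(Nc2c(C(=O)NCc3ccc(F)cc3)nc(Br)c3cccnc23)c1`) gives 8000 nM while compound 2 (`CN(C)c1ccc(CNC(=O)c2nc(Br)c3cccnc3c2N[C@H]2CC[C@H](N)CC2)cc1`) gives 5000 nM and these two values lie within the usual scatter of each other. Within the data shown here, the two structures differ in more than one place, so they offer no single-change step to work from. Compound 3 (`C[C@H](NC(=O)c1nc(Br)c2cccnc2c1N[C@H]1CC[C@H](N)CC1)c1ccc(F)cc1`) has no number at all in this assay. The result for compound 3 reads "not determined" (no result reported). It therefore holds no position on the scale, and nothing can be read directly from it.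

One change leads from it to compound 4 (`N[C@H]1CC[C@H](Nc2c(C(=O)NC3CCCCC3)nc(Br)c3cccnc23)CC1`), which carries cyclohexyl in place of 1-(4-fluorophenyl)ethyl on an amide-type nitrogen. Among the measured compounds shown here, the series contains no measured example of a change at this place, so the size of this step in this assay cannot be derived from the data. The working expectation is a step no larger than the scatter, with no direction assigned. The nearest measured structure is compound 2 at 5000 nM and that value serves as the anchor, with a wide margin on either side for the unmeasured change. Compound 4 is expected at 6000 nM (estimated range 2000 nM to 20000 nM).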

Compound 4, half-maximal inhibitory concentration: 5200 nM
For compound 4 the middle estimate is 1.2-fold (0.06 log units) above the measured one; low and high end bracket the measured number.
By their numbers in this assay, from the lowest: compounds 2, 4 and 1 (each within the scatter of the next).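

In this assay, the change on an amide-type nitrogen that can be read is cyclohexyl in place of 4-(dimethylamino)benzyl, with a 1.0-fold higher number from compound 2 to compound 4 (0.02 log units; within the scatter). Among these compounds, this is the first single-change step, and it shows that this read-out does not separate these two groups; within this pair, a non-aromatic ring of carbon only on that nitrogen gives a number in the same range as the substituted benzyl group. The step from compound 3 to compound 4 cannot be read, as compound 3 has no number, and nothing measured here bears on why the two groups read alike.

On these data alone, whether 1-(4-fluorophenyl)ethyl on the same nitrogen would read differently from cyclohexyl remains open, so the fluorine and the defined stereocentre of that group cannot be assessed. It is also open whether a carboxylic acid, a hydroxyl group or a longer alkyl chain on this amide-type nitrogen would move the number beyond the scatter, since the single step shown covers only two groups.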